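The source may report more compounds than this note shows. Statements on the series, on what has been measured and on what is new or still open speak of the compounds shown alone.

Working notes on the series. Compound 1 `CCOC(=O)[C@@H]1CCCN(S(=O)(=O)c2ccc(S(=N)(=O)N(CC)CC)cc2)C1` is the ester member of the set; in a functional assay on BXPC-3 cells (Homo sapiens) for inhibition, read by MTT assay, with a stated time of 7 days (on this read-out lower numbers stand for stronger inhibition and higher numbers for weaker inhibition), compound 1 gives 3600 nM. Among the three numbers measured in this assay, that value stands second highest. Compound 2 `CCN(CC)S(=O)(=O)c1ccc(S(=O)(=O)N2CCC[C@@H](C(=O)NC3CN(S(C)(=O)=O)C3)C2)cc1` gives 7400 nM in this assay, a higher number than compound 1 and a gap beyond the scatter. Compound 3 `CCN(CC)S(=O)(=O)c1ccc(S(=O)(=O)N2CCC[C@@H](C(=O)N3CC4(CCN(C(=O)OC(C)(C)C)C4)C3)C2)cc1` gives 900 nM in this assay, the lowest of the three and a gap from compound 1 that also lies beyond the scatter.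

Compound 4 `CCOC(=O)[C@@H]1CCCN(S(=O)(=O)c2ccc(C(=O)N(CC)CC)cc2)C1` has not yet been measured. It differs from compound 1 in one place: a group of 7 heavy atoms (5 carbon, 1 nitrogen, 1 oxygen; no ring) in place of a group of 8 heavy atoms (4 carbon, 2 nitrogen, 1 oxygen, 1 sulfur; no ring), on an aromatic carbon, so the diethylcarbamoyl group enters where the sulfur-bearing group on the aromatic ring leaves. Within the data shown here, no measured pair in the set shows this change, so the expectation rests on compound 1 alone. The step is expected to be small, at most around the edge of the scatter, and if anything toward a weaker number, because compound 1 at 3600 nM already sits among the weaker members and nothing measured points to a gain. The estimate for compound 4 in this assay is 5000 nM, within a range of 1500 nM to 15000 nM, which would correspond to a step of a 1.4-fold higher number from compound 1 to compound 4 (0.14 log units; within the scatter).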

Compound 4, half-maximal inhibitory concentration: 640 nM
Beside the measured number, compound 4's estimate is 7.8-fold (0.89 log units) above it; measured number below the stated range.
By their numbers in this assay, from the lowest: compounds 4 and 3 (each within the scatter of the next); then compound 1; then compound 2.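

In this assay, among these compounds, the change to diethylcarbamoyl gives a 5.6-fold lower number from compound 1 to compound 4 (0.75 log units; beyond the scatter), the first step in the set that can be read at a single place. It shows that the group on this aromatic carbon, para to a large group, matters for the read-out, with the ester side of compound 1 left unchanged. The step also replaces a sulfur-bearing group with a carbonyl-bearing one and takes the hydrogen-bond donors from 1 to 0, but no measurement shows which of these differences carries the step.

On these data alone, whether a carboxylic acid, a primary amine or a longer chain on the amide nitrogen would hold the number at this carbon stays open. So does whether diethylcarbamoyl would give a similar step on the core of compound 3.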